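The compounds below may be only part of what the source reports. "The series", "measured", "known", "first", "only" and "open" are said of these compounds alone.

Compound 2, structure `COc1ccc(C2C(C#N)=C(N)Oc3c2c(-c2ccccc2)nn3C)cc1F`, carries a phenyl on an aromatic carbon where compound 1, structure `COc1ccc(C2C(C#N)=C(N)Oc3c2c(C)nn3C)cc1F`, carries a methyl. In a functional assay on NCI-H2122 cells (Homo sapiens) for inhibition, read by microscopy, with a stated time of 10 days (on this read-out higher numbers stand for weaker inhibition and lower numbers for stronger inhibition), compound 1 gives 5800 nM. For compound 2 this assay reports only a limit, > 10000 nM, so it stands at the weak edge of the measured range, as does (the limit of > 10000 nM in this assay, at which 1 of the 3 values shown sits). Among the compounds with values here, the one measured step bearing on the core, an at least 1.7-fold higher number from compound 1 to compound 2 (0.23 log units; that floor lies within the scatter), is a floor only. Within the data shown here, compound 3, structure `Cc1nn(C)c2c1C(c1ccncc1)C(C#N)=C(N)O2`, with methyl on the aromatic carbon and pyridin-4-yl on the saturated ring carbon, gives 4100 nM in this assay; compound 1 and compound 3 thus sit in the same region, and no single-place step is defined between them.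

Compound 4, structure `Cn1nc(-c2ccccc2)c2c1OC(N)=C(C#N)C2c1cccnc1`, differs from compound 2 by pyridin-3-yl in place of 3-fluoro-4-methoxyphenyl on a saturated ring carbon. Among the measured compounds shown here, no measured step covers that swap directly. With the aryl change between compound 1 and compound 3 leaving the values close, the step that the limit leaves unreadable from compound 2 to compound 4 is expected to be small. Compound 4 is therefore estimated at 12000 nM, within 5000 nM to 30000 nM, with a fair chance that this assay again returns only a limit.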

Compound 4, half-maximal inhibitory concentration: > 10000 nM
Compound 4: a limit, no number; the forecaster's own chance of this, stated with the estimate: 60%; the middle value is on the limit's open side.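

Compound 2 and compound 4 both return only limits in this assay and no step can be read between them. Open, as far as these compounds go, is how far pyridin-3-yl in place of 3-fluoro-4-methoxyphenyl on a saturated ring carbon shifts inhibition when phenyl sits on the aromatic carbon.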